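Replacing 4-aminophenyl with 3-(trifluoromethyl)phenyl in compound 2

This account rests on a few compounds, and the source may have more. Where it says the series, first, only, none or still open, it means among the compounds named here.

Measured in a functional assay on MDA-MB-231 cells (Homo sapiens) for cytotoxicity, read by MTT assay, with a stated time of 48 h; a higher number here means a weaker inhibitor, a lower number a stronger inhibitor:
- Compound 1 `O=C(NCCCCC(c1ccc(F)cc1)c1ccc(F)cc1)Nc1ccc([N+](=O)[O-])cc1`: 6470 nM
- Compound 2 `Nc1ccc(NC(=O)NCCCCC(c2ccc(F)cc2)c2ccc(F)cc2)cc1`: > 20000 nM, a limit and not a number

Compound 2 stands at the limit of > 20000 nM in this assay, at which 1 of the 2 values shown sits. Compound 3 `O=C(NCCCCC(c1ccc(F)cc1)c1ccc(F)cc1)Nc1cccc(C(F)(F)F)c1` has 3-(trifluoromethyl)phenyl in place of 4-aminophenyl on an amide-type nitrogen. Within the data shown here, only one measured step bears on this change. It put amino in place of nitro and gave an at least 3.0-fold higher number from compound 1 to compound 2 (0.49 log units; beyond the scatter). Compound 3 no longer carries the amino group, so a return towards the number of compound 1 is expected in this assay. The expected change is an at least 3.3-fold lower number from compound 2 to compound 3 (0.52 log units; beyond the scatter), towards a lower number. Compound 3 is estimated at 6000 nM, with an expected range of 2500 nM to 16000 nM.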

Compound 3, half-maximal inhibitory concentration: 3380 nM
Compound 3: middle estimate off by 1.8-fold (0.25 log units), on the high side; the range from low to high includes it.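

In this assay, 3-(trifluoromethyl)phenyl in place of 4-aminophenyl gives an at least 5.9-fold lower number from compound 2 to compound 3 (0.77 log units; beyond the scatter), so recovery from the amino compound does not depend on nitro. The other comparison at this position gives a 1.9-fold lower number from compound 1 to compound 3 (0.28 log units; within the scatter), which leaves 4-nitrophenyl and 3-(trifluoromethyl)phenyl indistinguishable here. Compound 2 gives a limit and not a number: the limit of > 20000 nM in this assay, at which 1 of the 3 values shown sits.

The compounds shown leave open whether 4-(trifluoromethyl)phenyl would read like 3-(trifluoromethyl)phenyl, so the group and its place on the ring remain tangled. They also leave open how a nitrile or a carboxylic acid on that ring would read.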